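A few compounds are considered here, and "the series" means these few. Any claim that something is new, unique, unknown or untested is made for them only; others in the source may bear on it.

Compound 1, `CC(C)=CCc1cc(C(=O)Nc2cc3ccc(OCCCN4CCCCC4)c(C)c3oc2=O)ccc1O`: in a functional assay on SK-BR-3 cells (Homo sapiens) for antiproliferative activity (on this read-out higher numbers stand for weaker inhibition and lower numbers for stronger inhibition), compound 1 gives > 50000 nM, which is a limit of the assay and not a number.
Compound 2, `CCCNCCCOc1ccc2cc(NC(=O)c3ccc(O)c(CC=C(C)C)c3)c(=O)oc2c1C`: in this assay compound 2 gives 990 nM.
Compound 3, `CC(C)=CCc1cc(C(=O)Nc2cc3ccc(OCCCN(C)C(C)(C)C)c(C)c3oc2=O)ccc1O`: in this assay compound 3 gives 880 nM.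

Compound 3 thus holds the lowest of the two numbers, though the step between the two is a 1.1-fold lower number from compound 2 to compound 3 (0.05 log units; within the scatter). Compound 4, `CC(C)=CCc1cc(C(=O)Nc2cc3ccc(OCCCN[C@H](C)c4ccccc4)c(C)c3oc2=O)ccc1O`, differs from compound 3 by (1-phenylethyl)amino in place of methyl(tert-butyl)amino on a saturated chain carbon, three bonds along the chain from an oxygen on an aromatic ring. For the measured compounds named here, two measured steps bear on amine swaps at this place: an at least 50-fold lower number from compound 1 to compound 2 (1.70 log units; beyond the scatter) and an at least 56-fold lower number from compound 1 to compound 3 (1.75 log units; beyond the scatter), both large, both leaving piperidin-1-yl. Between the two acyclic amines, however, the step was only a 1.1-fold lower number from compound 2 to compound 3 (0.05 log units; within the scatter). A further acyclic swap is therefore expected to give a step of about a 1.1-fold lower number from compound 3 to compound 4 (0.04 log units; within the scatter), with no strong direction. Compound 4 is estimated at 800 nM, within a range of 250 nM to 3000 nM.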

Compound 4, half-maximal inhibitory concentration: 1000 nM
The estimate for compound 4 lay 1.3-fold (0.10 log units) below the measured number; the measured number falls inside the stated range.
By their numbers in this assay, from the lowest: compounds 3, 2 and 4 (each within the scatter of the next). At a limit, above all of these: compound 1.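

Adding an aromatic ring and a defined stereocentre to the amine changes little in this assay, with a 1.1-fold higher number from compound 3 to compound 4 (0.06 log units; within the scatter) and a 1.0-fold higher number from compound 2 to compound 4 (0.00 log units; within the scatter). Compounds 2, 3 and 4, whose amine nitrogens lie outside a ring, therefore sit together despite very different groups, whereas compound 1, with piperidin-1-yl, stands apart, with an at least 50-fold lower number from compound 1 to compound 4 (1.69 log units; beyond the scatter). Compound 1 gives > 50000 nM, which is a limit of the assay and not a number.

On these data alone, it remains open whether pyrrolidin-1-yl or morpholin-4-yl, which also hold the nitrogen in a ring, would match piperidin-1-yl. The mirror-image form of the 1-phenylethyl group is also an open case.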